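From a benzylamino to a phenoxy pendant on the core

A few compounds are considered here, and "the series" means these few. Any claim that something is new, unique, unknown or untested is made for them only; others in the source may bear on it.

Compound 1 `Nc1cc(N)c2nc(-c3ccccc3)c(NCc3ccc(F)cc3)nc2c1` gives 15500 nM in a functional assay on PC-3 cells (Homo sapiens) for inhibition, read by sulforhodamine B assay, with a stated time of 48 h (on this read-out lower numbers stand for stronger inhibition of growth and higher numbers for weaker inhibition of growth), the lowest of the two numbers in hand. Compound 2 `COc1ccc(CNc2nc3cc(N)cc(N)c3nc2-c2ccccc2)cc1` gives 27500 nM, and the step of a 1.8-fold higher number from compound 1 to compound 2 (0.25 log units; within the scatter) stays within the scatter. Compound 3 `Nc1cc(N)c2nc(-c3ccccc3)c(Oc3ccc(F)cc3)nc2c1` carries 4-fluorophenoxy in place of (4-fluorobenzyl)amino on an aromatic carbon. For the measured compounds named here, no measured step touches this change, since the only step on record alters the pendant ring substituent rather than the linker to the core. Compound 3 is therefore expected to stay near compound 1, with a 1.3-fold higher number from compound 1 to compound 3 (0.11 log units; within the scatter), and its estimated value is 20000 nM, within a range from 7000 nM to 60000 nM.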

Compound 3, concentration for total growth inhibition: 27500 nM
The estimate for compound 3 lay 1.4-fold (0.14 log units) below the measured number, and the stated range covers the measured number.
By their numbers in this assay, from the lowest: compounds 1, 2 and 3 (each within the scatter of the next).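

In this assay, the atom joining the pendant to the shared core can change at this position: 4-fluorophenoxy in place of (4-fluorobenzyl)amino gives a 1.8-fold higher number from compound 1 to compound 3 (0.25 log units; within the scatter). The earlier step altered only the pendant ring substituent, whereas this one swaps a group with 1 hydrogen-bond donor for a group with 0 hydrogen-bond donors and still stays within the scatter. No measurement in hand explains this result. From the compounds shown here alone, whether a thioether link or a longer chain between the core and the 4-fluorophenyl ring would also stay within the scatter remains open.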